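Sulfonamido-biphenyl acids: swapping the chlorophenyl for phenethyl

The compounds below may be only part of what the source reports. "The series", "measured", "known", "first", "only" and "open" are said of these compounds alone.

Measured compounds:
compound 1 `CCCCCCCCS(=O)(=O)Nc1cc(-c2ccccc2Cl)ccc1C(=O)O` — 26900 nM
compound 2 `CCCCCCCCS(=O)(=O)Nc1ccc(-c2ccccc2Cl)cc1C(=O)O` — 14400 nM

In an assay on mitochondria (strain BALB/c) for inhibition of glycerol-3-phosphate acyltransferase 1, mitochondrial (Mus musculus), read by scintillation counting, with a stated time of 10 min (on this read-out higher numbers stand for weaker inhibition and lower numbers for stronger inhibition), compound 1 gives 26900 nM and compound 2 gives 14400 nM. Compound 2 carries the lowest of the two numbers, but the gap to compound 1 lies within the scatter, so the two cannot be ordered.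

Compound 3 `CCCCCCCCS(=O)(=O)Nc1ccc(CCc2ccccc2)cc1C(=O)O` has not been measured. It differs from compound 2 in one place: phenethyl in place of 2-chlorophenyl on an aromatic carbon. The carboxy group and the sulfonamide chain of compound 2 stay where they are; only the group on the aromatic carbon changes.

Among the measured compounds shown here, no pair of measured compounds that differ in a single place is available, so the size of this step cannot be read from the data. The chain-linked phenyl is a different kind of substituent from the directly attached chlorophenyl, and the step of a 1.4-fold higher number from compound 2 to compound 3 (0.14 log units; within the scatter) is expected to stay within the scatter or drift modestly toward a higher number. Compound 3 is therefore estimated at 20000 nM, with a range from 6000 nM to 65000 nM.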

Compound 3, half-maximal inhibitory concentration: 37500 nM
For compound 3 the middle estimate is 1.9-fold (0.27 log units) below the measured one, and the stated range covers the measured number.
By their numbers in this assay, from the lowest: compounds 2, 1 and 3 (each within the scatter of the next, the first and the last beyond it).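

In this assay, among the compounds shown here, the change gives a 2.6-fold higher number from compound 2 to compound 3 (0.42 log units; beyond the scatter) and so provides the first step in this set that can be read at a single place. This position, para to a large group and meta to a carboxy group, therefore does respond to its substituent, with phenethyl giving modestly weaker inhibition than 2-chlorophenyl. The swap removes the chlorine and also puts a chain before the aromatic ring, and no measurement bears on why the number rises.

The compounds shown do not separate those two changes, so it remains open whether an unsubstituted phenyl, a benzyl or a longer chain ending in phenyl would fall nearer compound 2 or compound 3. Also open, going by these compounds, is whether phenethyl would give a step of similar size on the core of compound 1.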